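Compound 3 to compound 4: a changed amide group

The source may hold more compounds than are shown below. What is called first, only, known or untested is meant among the compounds shown, and "the series" means these compounds.

Measured in a functional assay on A20 cells (Mus musculus) for inhibition, with stated times of 1 h, 16 h and 24 h; on this read-out lower numbers stand for stronger inhibition and higher numbers for weaker inhibition:
Compound 1 `N#CCNC(=O)[C@@H]1C[C@@H](S(=O)(=O)c2ccccc2C(F)(F)F)C[C@H]1C(=O)N1CCOCC1`: 2 nM
Compound 2 `CC(C)(C#N)NC(=O)[C@@H]1C[C@@H](S(=O)(=O)c2ccccc2)C[C@H]1C(=O)N1CCOCC1`: 43 nM
Compound 3 `N#CC1(NC(=O)[C@@H]2C[C@@H](S(=O)(=O)c3ccccc3)C[C@H]2C(=O)N2CC3CCC(C2)O3)CC1`: 16 nM

Among these three numbers, compound 3 stands second highest. Compound 2 gives a higher number and compound 1 a lower one, both gaps beyond the usual scatter. Compound 4 `CN1CCN(C(=O)[C@@H]2C[C@H](S(=O)(=O)c3ccccc3)C[C@H]2C(=O)NC2(C#N)CC2)CC1` has not yet been measured in this assay. It differs from compound 3 on a carbonyl carbon, where 4-methylpiperazin-1-yl enters: a group of 7 heavy atoms (5 carbon, 2 nitrogen; one six-membered non-aromatic ring with 2 hetero atoms) in place of a group of 8 heavy atoms (6 carbon, 1 nitrogen, 1 oxygen; one five-membered non-aromatic ring with 1 hetero atom, one six-membered non-aromatic ring with 2 hetero atoms), on a carbonyl carbon. Among the compounds with values here, no measured pair here differs in one place alone, so the data offer no direct guide to this change. No shift beyond the scatter is expected, in either direction. The expected size is a 1.1-fold lower number from compound 3 to compound 4 (0.06 log units; within the scatter). For compound 4 the estimated value is 14 nM, with an expected range from 4 nM to 50 nM.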

Compound 4, half-maximal inhibitory concentration: 17 nM
Estimate against measurement, compound 4: 1.2-fold (0.08 log units) below, and the stated range covers the measured number.
By their numbers in this assay, from the lowest: compound 1; then compounds 3 and 4 (each within the scatter of the next); then compound 2.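

In this assay, replacing the two-ring group on the carbonyl carbon with 4-methylpiperazin-1-yl gives a 1.1-fold higher number from compound 3 to compound 4 (0.03 log units; within the scatter). Within the data shown here, this is the first direct reading at this position, and it shows that a single ring carrying two nitrogens in place of the two-ring group bearing an oxygen leaves the number within the scatter. Nothing available explains why the number holds across this change.

As far as these compounds go, how an open-chain dimethylamino group or a carboxylic acid at this carbonyl carbon would read remains open. So does whether this result would carry over to other cores, such as that of compound 1.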